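Tetrazolyl for sulfonylamino on the ring: expectation for compound 3

The source may report more compounds than this note shows. Statements on the series, on what has been measured and on what is new or still open speak of the compounds shown alone.

Compound 1 `CCCNc1cccnc1-c1ccc(C(=O)Nc2ccc(C(C)(C)C)cc2)cc1` gives 158 nM in a functional assay for antagonist activity at transient receptor potential cation channel subfamily V member 1 (Homo sapiens), read by FLIPR; on this read-out lower numbers stand for stronger inhibition and higher numbers for weaker inhibition. Among the compounds with values here, compound 2 `CC(C)(C)c1ccc(NC(=O)c2ccc(-c3ncccc3NS(=O)(=O)c3ccccc3)cc2)cc1` gives 91 nM in this assay; of the two numbers so far it holds the smaller, though a 1.7-fold lower number from compound 1 to compound 2 (0.24 log units; within the scatter). Compound 3 `CC(C)(C)c1ccc(NC(=O)c2ccc(-c3ncccc3-c3nn[nH]n3)cc2)cc1` carries 2H-tetrazol-5-yl in place of (phenylsulfonyl)amino on an aromatic carbon. Within the data shown here, the only measured step at this position, from compound 1 to compound 2, exchanged substituents on a nitrogen that now leaves altogether, so it bears on the change only loosely and sets no direction. Compound 3 is therefore expected to show a 1.6-fold higher number from compound 2 to compound 3 (0.22 log units; within the scatter), an estimated 150 nM with a range of 45 nM to 500 nM.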

Compound 3, half-maximal inhibitory concentration: > 4000 nM
Compound 3: only a limit was reported; the forecaster's own chance of this, stated with the estimate: 5%; middle value at least 26-fold (1.42 log units) away from the limit.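

In this assay compound 3 gives a limit, not a number: the limit of > 4000 nM in this assay, at which 1 of the 3 values shown sits.

On this aromatic carbon, two atoms from the ring nitrogen, the exchange for 2H-tetrazol-5-yl gives an at least 43-fold higher number from compound 2 to compound 3 (1.64 log units; beyond the scatter) and an at least 25-fold higher number from compound 1 to compound 3 (1.40 log units; beyond the scatter). Propylamino and (phenylsulfonyl)amino sit within the scatter of each other, so this position does not tolerate every group, a sensitivity the earlier pair did not show.

Still open, on these data alone, is whether the large steps go with losing the nitrogen on the ring or with the 2H-tetrazol-5-yl itself. A carboxylic acid or a methylamino group on this carbon would bear on that.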